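Cyclopentyl to Cyclopropyl on the Sulfonamide Nitrogen

The source may hold more compounds than are shown below. What is called first, only, known or untested is meant among the compounds shown, and "the series" means these compounds.

Measured so far:
compound 1 `O=C(Nc1ccc(S(=O)(=O)N2CCOCC2)cc1)C1C(C(=O)O)[C@H]2CC[C@@H]1O2` gives 24200 nM;
compound 2 `O=C(Nc1ccc(S(=O)(=O)NC2CCCC2)cc1)C1C(C(=O)O)[C@H]2CC[C@@H]1O2` gives 20100 nM.

Both values come from a functional assay on A549 cells (Homo sapiens) for cytotoxicity, read by MTT assay, with a stated time of 48 h; a lower number here means a stronger inhibitor, a higher number a weaker inhibitor. Among the compounds with values here, compound 2 has the lowest of the two numbers, but its only neighbour is compound 1, and the step of a 1.2-fold lower number from compound 1 to compound 2 (0.08 log units; within the scatter) lies within the scatter, so the two compounds cannot be told apart on these data.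

Compound 3 `O=C(Nc1ccc(S(=O)(=O)NC2CC2)cc1)C1C(C(=O)O)[C@H]2CC[C@@H]1O2` has not yet been measured. Its change from compound 2 is cyclopropyl in place of cyclopentyl on a sulfonamide nitrogen. Within the data shown here, the one measured step, cyclopentylamino in place of morpholin-4-yl, bears on it only loosely, as it also alters the group on the sulfonyl sulfur, and it produced no movement beyond the scatter. Nothing here therefore supports a large step in either direction. Compound 3 is expected to sit close to compound 2, with the step of a 1.2-fold higher number from compound 2 to compound 3 (0.09 log units; within the scatter) expected to stay within the scatter. The estimate for compound 3 in this assay is 25000 nM, with a range from 10000 nM to 60000 nM.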

Compound 3, half-maximal inhibitory concentration in the A549 assay: 34300 nM
For compound 3 the middle estimate is 1.4-fold (0.14 log units) below the measured one; measured number inside the range.
By their numbers in the A549 assay, from the lowest: compounds 2, 1 and 3 (each within the scatter of the next).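

In the A549 assay, the change at the sulfonamide nitrogen gives a 1.7-fold higher number from compound 2 to compound 3 (0.23 log units; within the scatter), and replacing morpholin-4-yl on the sulfonyl sulfur with cyclopropylamino gives a 1.4-fold higher number from compound 1 to compound 3 (0.15 log units; within the scatter), so neither step can be told apart from repeat-measurement noise, and cyclopropyl and cyclopentyl cannot be separated at this position. In a physicochemical assay for lipophilicity (a higher number here means a more lipophilic compound, a lower number a more polar compound), compound 2 gives 0.2 and compound 3 gives 0.2, so the two compounds cannot be separated on this measure either. No measurement here offers an explanation for these numbers.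

The compounds shown leave open whether a phenyl ring or a longer alkyl chain on the sulfonamide nitrogen would produce a step beyond the scatter. They also leave open what a methyl ester in place of the carboxylic acid would do.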